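This account rests on a few compounds, and the source may have more. Where it says the series, first, only, none or still open, it means among the compounds named here.

Measured in a functional assay on CNE-2 cells (Homo sapiens) for cytotoxicity, read by MTT assay, with a stated time of 72 h; a higher number here means a weaker inhibitor, a lower number a stronger inhibitor:

Compound 1 `COc1cc2ncnc(NNC(=S)NC(=O)c3ccccc3OC)c2cc1OC` gives 8410 nM
Compound 2 `COc1cc2ncnc(NNC(=S)NC(=O)c3ccc(F)cc3)c2cc1OC` gives 16100 nM
Compound 3 `O=C(NC(=S)NNc1ncnc2ccccc12)c1ccc(Cl)cc1` gives 1530 nM

Compound 2 stands at the highest number of the three. Its nearest neighbour is compound 1, and the step of a 1.9-fold higher number from compound 1 to compound 2 (0.28 log units; within the scatter) lies within the scatter. Among the measured compounds shown here, compound 3 sits at a clearly lower number, but it differs from compound 2 in more than one place, so no single step connects them.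

Compound 4 `COc1cc2ncnc(NNC(=S)NC(=O)c3ccccc3)c2cc1OC` has not been measured yet. It differs from compound 2 by hydrogen in place of fluoro on an aromatic carbon. For the measured compounds named here, no measured pair shows this exact change. Going by the values given here, the only single-place step available, from compound 1 to compound 2, exchanges one substituted phenyl for another and stays within the scatter, so in this assay a step of modest size is expected, with no clear direction. For compound 4 the estimated step is a 1.3-fold lower number from compound 2 to compound 4 (0.13 log units; within the scatter). Compound 4 is therefore expected to give about 12000 nM, within the range 5000 nM to 30000 nM.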

Compound 4, half-maximal inhibitory concentration: 8180 nM
Estimate against measurement, compound 4: 1.5-fold (0.17 log units) above; the range from low to high includes it.
By their numbers in this assay, from the lowest: compound 3; then compounds 4, 1 and 2 (each within the scatter of the next).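

In this assay, hydrogen in place of fluoro gives a 2.0-fold lower number from compound 2 to compound 4 (0.29 log units; within the scatter), and hydrogen in place of methoxy gives a 1.0-fold lower number from compound 1 to compound 4 (0.01 log units; within the scatter). The bare benzoyl compound now serves as a reference point, and neither the fluoro nor the methoxy group, each at its own place on the ring, separates from it beyond the scatter. Nothing available explains these small steps. Still open, as far as these compounds go, is whether an amine or a carboxylic acid on this aromatic ring would shift the number beyond the scatter.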